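The compounds below may be only part of what the source reports. "The series", "measured", "known", "first", "only" and "open" are said of these compounds alone.

In a functional assay on HCT-116 cells (Homo sapiens) for antiproliferative activity, read by MTT assay, with a stated time of 72 h (on this read-out higher numbers stand for weaker inhibition and lower numbers for stronger inhibition), compound 1 `NC1=NC2(CCOCC2)N(OCCCOc2ccccc2)C(N)=N1` gives 6010 nM, compound 2 `NC1=NC2(CCOCC2)N(OCCCOc2ccc(F)cc2)C(N)=N1` gives 3280 nM and compound 3 `Cc1cc(C)cc(OCCCON2C(N)=NC(N)=NC23CCOCC3)c1` gives 190 nM, the lowest of the three numbers. The fluoro change is small, a 1.8-fold lower number from compound 1 to compound 2 (0.26 log units; within the scatter), whereas 3,5-dimethylphenyl brings large steps, a 32-fold lower number from compound 1 to compound 3 (1.50 log units; beyond the scatter) and a 17-fold lower number from compound 2 to compound 3 (1.24 log units; beyond the scatter). Compound 4 `NC1=NC2(CCOCC2)N(OCCCOc2ccccc2Br)C(N)=N1` differs from compound 3 as follows: 2-bromophenyl in place of 3,5-dimethylphenyl on an oxygen on a saturated carbon, with 2-bromophenyl in place of 3,5-dimethylphenyl on an oxygen on a saturated carbon. Within the data shown here, no measured step covers 2-bromophenyl, so the expectation rests on losing 3,5-dimethylphenyl: a large rise in this assay, most of the way back toward the values of compound 1 and compound 2. The expected step is a 9.5-fold higher number from compound 3 to compound 4 (0.98 log units; beyond the scatter). The estimate for compound 4 is 1800 nM, expected between 400 nM and 6500 nM.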

Compound 4, half-maximal inhibitory concentration: 30 nM
Beside the measured number, compound 4's estimate is 60-fold (1.78 log units) above it; measured number outside the range, below it.
By their numbers in this assay, from the lowest: compound 4; then compound 3; then compounds 2 and 1 (each within the scatter of the next).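

In this assay the group at this position tolerates more than one pattern of substitution: 3,5-dimethylphenyl is not needed for a low number, as 2-bromophenyl goes further (a 6.3-fold lower number from compound 3 to compound 4 (0.80 log units; beyond the scatter)). Going from phenyl to 2-bromophenyl brings a large step (a 200-fold lower number from compound 1 to compound 4 (2.30 log units; beyond the scatter)), unlike the small fluoro change, and 2-bromophenyl also stands far from 4-fluorophenyl (a 110-fold lower number from compound 2 to compound 4 (2.04 log units; beyond the scatter)). Nothing shown here accounts for this result. The compounds shown leave open whether 2-chlorophenyl or 2-methoxyphenyl would match 2-bromophenyl, and how a longer chain would affect compound 4.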